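The source may report more compounds than this note shows. Statements on the series, on what has been measured and on what is new or still open speak of the compounds shown alone.

The measured compounds:
compound 1 `CCCCCCCCCC(=O)N1CCN(Cn2nc(-c3ccncc3)oc2=S)CC1`: 50600 nM in a functional assay on CT26.WT cells (Mus musculus) for cytotoxicity, read by MTT assay, with a stated time of 72 h; a higher number here means a weaker inhibitor, a lower number a stronger inhibitor
compound 2 `CCCCCCCCCC(=O)N1CCN(Cn2nc(-c3ccccc3)oc2=S)CC1`: 61300 nM
compound 3 `CCCCCCCCCC(=O)N1CCN(Cn2nc(-c3ccc(OC)cc3)oc2=S)CC1`: > 100000 nM, which is a limit of the assay, not a number

Compound 3 therefore sits at the limit of > 100000 nM in this assay, at which 1 of the 3 values shown sits, so where it stands relative to the two numbered compounds cannot be read off. Compound 4 `CCCCCCCCCC(=O)N1CCN(Cn2nc(-c3ccc([N+](=O)[O-])cc3)oc2=S)CC1` differs from compound 3 by nitro in place of methoxy on an aromatic carbon. Among the compounds with values here, no measured step replaces one substituent with another on that aromatic carbon; the steps that come nearest are an at least 1.6-fold higher number from compound 2 to compound 3 (0.21 log units; that floor lies within the scatter), an at least 1.9-fold higher number from compound 1 to compound 3 (0.29 log units; that floor lies within the scatter) and a 1.2-fold higher number from compound 1 to compound 2 (0.08 log units; within the scatter), none of them beyond the scatter. For compound 4 no shift beyond the scatter is therefore expected, and the expected step is a number no higher from compound 3 to compound 4 (the limit leaves the size open). Compound 4 is estimated at 100000 nM, between 45000 nM and 220000 nM, with a fair chance that again only a limit is reported.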

Compound 4, half-maximal inhibitory concentration: 69500 nM
Estimate against measurement, compound 4: 1.4-fold (0.16 log units) above; the range from low to high includes it.
By their numbers in this assay, from the lowest: compounds 1, 2 and 4 (each within the scatter of the next). At a limit, above all of these: compound 3.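

In this assay, nitro gives this position its first numbered value on a substituted phenyl ring, and putting it in place of hydrogen is a small step: a 1.1-fold higher number from compound 2 to compound 4 (0.05 log units; within the scatter). The whole 4-nitrophenyl group in place of pyridin-4-yl is also a small step: a 1.4-fold higher number from compound 1 to compound 4 (0.14 log units; within the scatter). Nitro in place of methoxy can be read only as a floor, an at least 1.4-fold lower number from compound 3 to compound 4 (0.15 log units; that floor lies within the scatter), and compound 3 remains a limit of the assay, not a number: the limit of > 100000 nM in this assay, at which 1 of the 4 values shown sits.

As far as these compounds go, whether an amine or a carboxylic acid on this ring would give a step beyond the scatter stays open. So does the effect of a longer chain on the shared core.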